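From compound 2 to compound 4: a ring exchange

The source may report more compounds than this note shows. Statements on the series, on what has been measured and on what is new or still open speak of the compounds shown alone.

In an ADME assay on microsomes from liver (Rattus norvegicus) for metabolic stability (a lower number here means that the compound disappears faster, a higher number that the compound lasts longer), compound 2 `CC(C)C(Nc1nnc[nH]1)c1ccc(-c2ccc3cccc(F)c3c2)[nH]c1=O` gives 1.29 h, the higher of the two exact numbers available. Compound 1 `CC(C)C(c1ccc(-c2ccc3cccc(F)c3c2)[nH]c1=O)N1CCCCS1(=O)=O` gives 0.07 h. The gap between these two is an 18-fold higher number from compound 1 to compound 2 (1.27 log units; beyond the scatter), so one group exchange at this carbon was enough to shift the half-life strongly. Compound 3 `CCn1ncc2c(F)cc(-c3ccc(C(CC)(CC)c4nncn4C)c(=O)[nH]3)cc21` gives > 3 h, which is a limit of the assay and not a number. For the measured compounds named here, no measured step connects compound 3 to the others, so it offers no guide here.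

Compound 4 `CC(C)C(c1ccc(-c2ccc3cccc(F)c3c2)[nH]c1=O)N1CCCCC1=O` is changed at the same carbon as that measured step: 2-oxopiperidin-1-yl in place of (4H-1,2,4-triazol-3-yl)amino on a saturated chain carbon bound to an aromatic carbon and a saturated chain carbon. Compound 2 thus loses its five-membered aromatic ring, and a six-membered non-aromatic ring takes its place. Going by the values given here, compound 1 also carries a six-membered non-aromatic ring at this carbon, and the measured step of an 18-fold higher number from compound 1 to compound 2 (1.27 log units; beyond the scatter) is the only evidence for this kind of exchange. The two six-membered rings are not the same, and a single step is thin support, so the range must stay wide. A large downward step is expected, namely an 8.6-fold lower number from compound 2 to compound 4 (0.93 log units; beyond the scatter). Compound 4 is estimated at 0.15 h, with an expected range from 0.05 h to 0.5 h.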

Compound 4, half-life: 0.102 h
Compound 4: middle estimate off by 1.5-fold (0.17 log units), on the high side; the measured number falls inside the stated range.
By their numbers in this assay, from the lowest: compounds 1 and 4 (each within the scatter of the next); then compound 2. At a limit, above all of these: compound 3.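

For the compounds shown here, at the saturated chain carbon bound to an aromatic carbon and a saturated chain carbon, the earlier compounds offered a single exchange, and that exchange also changed whether sulfur was present. In this assay, compound 4 gives a second exchange at this carbon, with 2-oxopiperidin-1-yl in place of (4H-1,2,4-triazol-3-yl)amino and no sulfur involved: a 13-fold lower number from compound 2 to compound 4 (1.10 log units; beyond the scatter). The two six-membered non-aromatic rings cannot be told apart in this assay, as a 1.5-fold higher number from compound 1 to compound 4 (0.16 log units; within the scatter), so the sulfur-bearing ring of compound 1 is not needed for the short half-life, and among these three compounds, which share the same core, only compound 2 stands apart.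

From the compounds shown here alone, it remains open whether the longer half-life of compound 2 belongs to the five-membered aromatic ring itself or to the amino nitrogen that attaches it, and a plain amine or a phenyl ring at this carbon would help to separate the two. Nothing measured here accounts for the size of these steps.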